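The compounds below may be only part of what the source reports. "The series", "measured", "known", "first", "only" and "open" are said of these compounds alone.

Measured in a functional assay on PC-3 cells (Homo sapiens) for antiproliferative activity, read by MTT assay, with a stated time of 48 h; on this read-out higher numbers stand for weaker inhibition and lower numbers for stronger inhibition:
compound 1 `CCn1c(C(=O)NCCCN(C)C)ccc1C(CC)(CC)c1ccc(OCCC(O)(CC)CC)c(C)c1` gives 2150 nM;
compound 2 `CCn1c(C(=O)NCCN)ccc1C(CC)(CC)c1ccc(OCCC(O)(CC)CC)c(C)c1` gives 2420 nM;
compound 3 `CCOc1ccc(NC(=O)c2ccc(C(CC)(CC)c3ccc(OCCC(O)(CC)CC)c(C)c3)n2CC)cc1` gives > 50000 nM, which is a limit of the assay and not a number.

Compound 2 is one of the two compounds with a reported number, and the step of a 1.1-fold higher number from compound 1 to compound 2 (0.05 log units; within the scatter) lies within the scatter, so compound 1 and compound 2 stand together. Compound 4 `CCC(C)C(NC(=O)c1ccc(C(CC)(CC)c2ccc(OCCC(O)(CC)CC)c(C)c2)n1CC)C(=O)OC` differs from compound 2 by a group of 9 heavy atoms (7 carbon, 2 oxygen; no ring) in place of a group of 3 heavy atoms (2 carbon, 1 nitrogen; no ring), on an amide-type nitrogen. Among the measured compounds shown here, two measured steps bear on this: an at least 20-fold higher number from compound 2 to compound 3 (1.31 log units; beyond the scatter) and an at least 23-fold higher number from compound 1 to compound 3 (1.36 log units; beyond the scatter), both large and known only through (the limit of > 50000 nM in this assay, at which 1 of the 3 values shown sits). In each of them a nitrogen-bearing chain on the amide-type nitrogen gave way to a group of carbon and oxygen only, and this assay responded with a large loss. The group entering in compound 4 likewise holds only carbon and oxygen, so a large step toward a higher number in this assay is expected, though perhaps short of the limit. Compound 4 is therefore estimated at 15000 nM (range 4000 nM to 50000 nM), an expected step of a 6.2-fold higher number from compound 2 to compound 4 (0.79 log units; beyond the scatter).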

Compound 4, half-maximal inhibitory concentration: > 50000 nM
Compound 4 ended at the assay's limit (the forecaster's own chance of this, stated with the estimate: 35%); middle value at least 3.3-fold (0.52 log units) away from the limit.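

In this assay, the result shows that the large loss on this amide-type nitrogen does not depend on an aromatic ring in the entering group: the group in compound 3 holds one, the group in compound 4 has no ring, and the steps are an at least 20-fold higher number from compound 2 to compound 4 (1.31 log units; beyond the scatter) and an at least 23-fold higher number from compound 1 to compound 4 (1.36 log units; beyond the scatter). Among the four compounds, the two with a nitrogen-bearing chain on this nitrogen give numbers and the two with carbon and oxygen only do not, with no compound going against this. The step from compound 3 to compound 4 cannot be read, as each value is a limit of the assay and not a number: the limit of > 50000 nM in this assay, at which 2 of the 4 values shown sit.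

The compounds shown leave open whether the chain nitrogen itself matters, which a hydroxyethyl chain in place of 2-aminoethyl would address. They also leave open whether a carboxylic acid in place of the ester of compound 4 would stay at the limit.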